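One Chloro Fewer: From Compound 2 to Compound 3

This account rests on a few compounds, and the source may have more. Where it says the series, first, only, none or still open, it means among the compounds named here.

Measured in a functional assay on UACC-62 cells (Homo sapiens) for cytotoxicity, read by sulforhodamine B assay, with a stated time of 48 h; a higher number here means a weaker inhibitor of growth, a lower number a stronger inhibitor of growth:
Compound 1 `ClCc1ccc(Cn2cnc3c(Cl)ncnc32)cc1`: 33900 nM
Compound 2 `ClCc1ccccc1Cn1cnc2c(Cl)nc(Cl)nc21`: 2630 nM

Compound 2 holds the lowest number of the two; compound 1 stands well above it, beyond the scatter, though the two differ in more than one place and only their values can be set side by side. Compound 3 `ClCc1ccccc1Cn1cnc2c(Cl)ncnc21` differs from compound 2 by hydrogen in place of chloro on an aromatic carbon. Within the data shown here, no single step among the measured compounds isolates this change. A moderate rise in this assay is expected, because compound 1 without that chloro gives 33900 nM. Compound 3 is estimated at 8000 nM (range 2500 nM to 30000 nM). The expected step is a 3.0-fold higher number from compound 2 to compound 3 (0.48 log units; beyond the scatter).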

Compound 3, concentration for total growth inhibition: 6600 nM
Compound 3: the middle estimate sits 1.2-fold (0.08 log units) above what was measured, and the stated range covers the measured number.
By their numbers in this assay, from the lowest: compound 2; then compound 3; then compound 1.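

In this assay, among these compounds, the change isolates the chloro on the aromatic carbon between two ring nitrogen atoms for the first time, giving a 2.5-fold higher number from compound 2 to compound 3 (0.40 log units; beyond the scatter) as a modest step. The chloro at this position therefore adds to growth inhibition, but compound 3 still gives 6600 nM without it. Nothing shown explains the size of this step. The compounds shown leave open whether an amine or a methoxy group at this position would match chloro or hydrogen. They also leave open whether the same step would hold with the chloromethyl group placed elsewhere.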